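Replacing the Benzylamine of Compound 2 with a Hydroxyethyl Chain

A few compounds are considered here, and "the series" means these few. Any claim that something is new, unique, unknown or untested is made for them only; others in the source may bear on it.

Compound 1, `CNCc1c(OC)cc(Oc2cccc(Nc3ccccc3)c2)cc1OC`, gives 7430 nM in a functional assay on HT-29 cells (Homo sapiens) for inhibition, read by MTT assay, with a stated time of 72 h; a higher number here means a weaker inhibitor, a lower number a stronger inhibitor.
Compound 2, `COc1cc(Oc2cccc(Nc3ccccc3)c2)cc(OC)c1CNCc1ccc(C)cc1`, gives 3880 nM in this assay.
Compound 3, `COc1ccc([C@@H](C)NCc2c(OC)cc(Oc3cccc(Nc4ccccc4)c3)c(OC)c2OC)cc1`, gives 1630 nM in this assay.

Among these three numbers compound 2 stands second highest. Its nearest neighbour is compound 1, and the step of a 1.9-fold lower number from compound 1 to compound 2 (0.28 log units; within the scatter) lies within the scatter, so the two cannot be ordered. Compound 3 stands furthest away, with a number that is beyond the scatter lower than that of compound 2.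

Compound 4, `COc1cc(Oc2cccc(Nc3ccccc3)c2)cc(OC)c1CCO`, has not yet been measured in this assay. It differs from compound 2 in one place: hydroxymethyl in place of (4-methylbenzyl)amino on a saturated chain carbon bound to an aromatic carbon.

Among the compounds with values here, only the step from compound 1 to compound 2 touches the same part of the structure, and that step, a 1.9-fold lower number from compound 1 to compound 2 (0.28 log units; within the scatter), stayed within the scatter when the 4-methylphenyl group was added onto the saturated chain carbon bound to the amine nitrogen. No measured step removes the amine nitrogen itself, so the present change goes further than anything shown. Since compound 1, which keeps the nitrogen but loses the aryl group, gives 7430 nM, and compound 3 with a still larger group on the amine gives 1630 nM, the shown numbers point toward weaker inhibition as this side of the molecule is pared back. For compound 4 the expected step is therefore a 3.1-fold higher number from compound 2 to compound 4 (0.49 log units; beyond the scatter), toward a higher number in this assay. Compound 4 is estimated at 12000 nM, with a range from 4000 nM to 40000 nM.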

Compound 4, half-maximal inhibitory concentration: 13900 nM
Beside the measured number, compound 4's estimate is 1.2-fold (0.06 log units) below it; measured number inside the range.
By their numbers in this assay, from the lowest: compound 3; then compounds 2, 1 and 4 (each within the scatter of the next, the first and the last beyond it).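

In this assay, within the data shown here, hydroxymethyl in place of (4-methylbenzyl)amino gives a 3.6-fold higher number from compound 2 to compound 4 (0.55 log units; beyond the scatter) and is the first single change on this side of the molecule to clear the scatter, though the step is only modest. Hydroxymethyl in place of methylamino gives a 1.9-fold higher number from compound 1 to compound 4 (0.27 log units; within the scatter) and stays within the scatter, so compound 1 and compound 4 cannot be ordered, and losing the amine nitrogen from the small methylamino group produces no readable change in the number. The readable loss therefore appears only against compound 2, which carries the 4-methylbenzyl group, although the step from compound 1 to compound 2 alone could not be read, and nothing available accounts for these numbers.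

The change from compound 2 to compound 4 removes the amine nitrogen and the 4-methylbenzyl group together, so their separate shares in the step remain unresolved. A 4-methylbenzyl ether on the same chain, with oxygen standing where the nitrogen stands, would keep the aromatic ring without the amine, while a carboxylic acid at the end of the chain would show how far the 2-hydroxyethyl end can be varied.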